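The compounds below may be only part of what the source reports. "The series", "measured", "known", "first", "only" and "open" are said of these compounds alone.

Notes on the step from compound 2 `CC[C@@H]1CC[C@@H](C(=O)N2CCN(C(C)=O)CC2)N1C(=O)C1=C(C(C)C)N2C(=N[C@@](C)(c3ccc(Cl)cc3)[C@H]2c2ccc(Cl)cc2)S1` to compound 4 `CC[C@@H]1CC[C@@H](C(=O)N2CCN(C(C)=O)[C@H](C)C2)N1C(=O)C1=C(C(C)C)N2C(=N[C@@](C)(c3ccc(Cl)cc3)[C@H]2c2ccc(Cl)cc2)S1`. In a physicochemical assay for solubility, read by HPLC, in phosphate buffer, at pH 6.8 (on this read-out lower numbers stand for lower solubility and higher numbers for higher solubility), compound 2 gives 34 ug/mL. Compound 1 `CC(C)C1=C(C(=O)N2[C@H](C)CC[C@H]2C(=O)N2CCN(C)CC2)SC2=N[C@@](C)(c3ccc(Cl)cc3)[C@@H](c3ccc(Cl)cc3)N21` gives 45 ug/mL, and compound 3 `CC(C)C1=C(C(=O)N2[C@H](C)CC[C@H]2C(=O)N2CCN(C)C(C)(C)C2)SC2=N[C@@](C)(c3ccc(Cl)cc3)[C@@H](c3ccc(Cl)cc3)N21` gives 30 ug/mL. All three numbers lie within the usual scatter of one another, so compound 2 sits among them with no separate place of its own.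

The change is methyl in place of hydrogen on a saturated ring carbon, in short methyl in place of hydrogen on a saturated ring carbon. Within the data shown here, one measured step bears on it: a 1.5-fold lower number from compound 1 to compound 3 (0.18 log units; within the scatter), where a larger group with a six-membered non-aromatic ring replaces a smaller one on a carbonyl carbon. That step stayed within the scatter, though it belongs to a different pair and a different group, so it is only a loose guide. No step beyond the scatter is therefore expected in this assay. The expected step is a 1.1-fold lower number from compound 2 to compound 4 (0.05 log units; within the scatter). For compound 4 the estimated value is 30 ug/mL, with an expected range of 15 ug/mL to 55 ug/mL.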

Compound 4, solubility: 25 ug/mL
Estimate against measurement, compound 4: 1.2-fold (0.08 log units) above, and the stated range covers the measured number.
By their numbers in this assay, from the lowest: compounds 4, 3, 2 and 1 (each within the scatter of the next).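

In this assay, methyl in place of hydrogen on this saturated ring carbon, next to the ring atom that bears an acetyl group, gives a 1.4-fold lower number from compound 2 to compound 4 (0.13 log units; within the scatter), so the position takes the methyl with no step beyond the scatter. The earlier step, a 1.5-fold lower number from compound 1 to compound 3 (0.18 log units; within the scatter), concerned a different group on a carbonyl carbon, whereas this pair reads the methyl alone, with the acetyl group in place and the rest of the molecule the same. Nothing at hand gives a reason for the size of this step.

The compounds shown cover only methyl and hydrogen on this ring carbon, with a single spatial arrangement of the methyl. From the compounds shown here alone, whether an ethyl chain, a hydroxymethyl group or an amine at the same carbon would also stay within the scatter in this assay remains open.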